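The source may hold more compounds than are shown below. What is called first, only, known or untested is meant among the compounds shown, and "the series" means these compounds.

In a functional assay on L1210 cells (Mus musculus) for antiproliferative activity, read by cell counting, with a stated time of 96 h (on this read-out lower numbers stand for stronger inhibition and higher numbers for weaker inhibition), compound 1 (`COc1ccc(Oc2ccccc2NC(C)=C2C(=O)CC(c3ccccc3)CC2=O)cc1OC`) gives 65 nM and compound 2 (`COc1cc(Oc2ccccc2NC(C)=C2C(=O)CC(c3ccccc3)CC2=O)ccc1N`) gives 26 nM. Within the data shown here, compound 2 therefore holds the lower of the two numbers so far. Among the measured compounds shown here, the only measured step is a 2.5-fold lower number from compound 1 to compound 2 (0.40 log units; beyond the scatter), with amino in place of methoxy on an aromatic carbon, a modest change but beyond the scatter.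

Compound 3 (`CC(Nc1ccccc1Oc1ccc(C(C)O)cc1)=C1C(=O)CC(c2ccccc2)CC1=O`) keeps the shared core and alters the same aryl group: 4-(1-hydroxyethyl)phenyl in place of 4-amino-3-methoxyphenyl on an oxygen on an aromatic ring. Here 4-(1-hydroxyethyl)phenyl stands in place of 4-amino-3-methoxyphenyl on an oxygen on an aromatic ring, so both the amino and the methoxy groups go. For the measured compounds named here, no measured compound carries a 1-hydroxyethyl group, so the data give only indirect guidance. The nearest evidence is compound 2, whose amino group came with a 2.5-fold lower number from compound 1 to compound 2 (0.40 log units; beyond the scatter). Compound 3 gives that group up, so a modest move towards a higher number is expected, though with wide uncertainty. The expected step is a 3.1-fold higher number from compound 2 to compound 3 (0.49 log units; beyond the scatter). For compound 3 the estimated value is 80 nM, within a range of 25 nM to 260 nM.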

Compound 3, half-maximal inhibitory concentration: 58 nM
For compound 3 the middle estimate is 1.4-fold (0.14 log units) above the measured one; measured number inside the range.
By their numbers in this assay, from the lowest: compound 2; then compounds 3 and 1 (each within the scatter of the next).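

In this assay, the aryl group on an oxygen on an aromatic ring can lose both its amino and its methoxy groups without a readable difference from compound 1: 4-(1-hydroxyethyl)phenyl in place of 3,4-dimethoxyphenyl gives [ a 1.1-fold lower number from compound 1 to compound 3 (0.05 log units; within the scatter) ], so two differently substituted aryl groups cannot be told apart here. The same replacement starting from 4-amino-3-methoxyphenyl gives [ a 2.2-fold higher number from compound 2 to compound 3 (0.35 log units; beyond the scatter) ], which is of modest size, and this shows that compound 2 stands apart from both other compounds, not only from compound 1. Among these three compounds, then, only the aryl group that carries the amino group gives a number separate from the others, while nothing measured here explains this difference.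

As far as these compounds go, it remains open whether the amino group accounts for this alone: a plain 4-aminophenyl group would separate it from the methoxy group that accompanies it in compound 2. From the compounds shown here alone, an ethyl or an acetyl group in place of 1-hydroxyethyl would test whether the hydroxyl matters, and how a carboxylic acid or a longer chain would behave on this aryl group also remains open.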